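The source may report more compounds than this note shows. Statements on the series, on what has been measured and on what is new or still open speak of the compounds shown alone.

Compound 1, `COc1ccc(CNc2cc(OC)c(OC)c(OC)c2)cc1`, gives 18400 nM in a functional assay on HCT-116 cells (Homo sapiens) for inhibition, read by MTT assay, with a stated time of 48 h; a higher number here means a weaker inhibitor, a lower number a stronger inhibitor. Compound 2, `COc1ccc(CNc2cc(OC)c(OC)c(OC)c2)cc1[N+](=O)[O-]`, gives 18200 nM. Compound 3, `COc1ccc(CNc2cc(OC)c(OC)c(OC)c2)cc1Cl`, gives 41700 nM.

Among these three, compound 1 stands second highest; its number and that of compound 2 fall within the scatter of each other, as the step of a 1.0-fold lower number from compound 1 to compound 2 (0.00 log units; within the scatter) shows, while the step of a 2.3-fold higher number from compound 1 to compound 3 (0.36 log units; beyond the scatter) sets compound 3 apart as a modestly weaker inhibitor.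

Compound 4, `COc1cc(NCc2ccc(C)cc2)cc(OC)c1OC`, differs from compound 1 in one place: methyl in place of methoxy on an aromatic carbon. Among the measured compounds shown here, none of the measured steps touches this position. The steps of a 1.0-fold lower number from compound 1 to compound 2 (0.00 log units; within the scatter) and a 2.3-fold higher number from compound 1 to compound 3 (0.36 log units; beyond the scatter) both concern a hydrogen on an aromatic carbon elsewhere on the same ring, and the step of a 2.3-fold higher number from compound 2 to compound 3 (0.36 log units; beyond the scatter) swaps the groups at that same place; none of them exchanges methoxy for methyl. With no direct guide, the account expects for compound 4 a step of a 1.1-fold higher number from compound 1 to compound 4 (0.04 log units; within the scatter) that stays within the scatter. Compound 4 is therefore estimated at 20000 nM, in the range 8000 nM to 50000 nM.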

Compound 4, half-maximal inhibitory concentration: > 80000 nM
Compound 4: a limit, no number; the forecaster's own chance of this, stated with the estimate: 10%; middle value at least 4.0-fold (0.60 log units) from the limit.
By their numbers in this assay, from the lowest: compounds 2 and 1 (each within the scatter of the next); then compound 3. At a limit, above all of these: compound 4.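

At this place, on an aromatic carbon para to a large group, methyl in place of methoxy gives an at least 4.3-fold higher number from compound 1 to compound 4 (0.63 log units; beyond the scatter) in this assay. This is the first change shown at this place, and it shows that the methoxy cannot be exchanged for methyl here without a weaker result, whereas nitro in place of hydrogen elsewhere on the same ring left the number within the scatter. As far as these compounds go, for compound 4 the result is a limit and not a number, so the full size of the step stays unknown: the limit of > 80000 nM in this assay, at which 1 of the 4 values shown sits.

From the compounds shown here alone, whether a hydroxyl, an ethoxy or a longer alkoxy chain at this place would keep the number of compound 1 stays open. So does whether an amine or a fluoro there would behave like the methyl of compound 4.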